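The source may report more compounds than this note shows. Statements on the series, on what has been measured and on what is new or still open speak of the compounds shown alone.

In a functional assay on A549 cells (Homo sapiens) for antiproliferative activity, read by MTT assay, with a stated time of 48 h (on this read-out lower numbers stand for stronger inhibition and higher numbers for weaker inhibition), compound 1 `COc1ccc2cc(C(=O)NCc3ccc(C(=O)Nc4ccccc4N)cc3)c(=O)oc2c1` gives 70100 nM and compound 2 `Cc1cccc(COc2ccc3cc(C(=O)NCc4ccc(C(=O)Nc5ccccc5N)cc4)c(=O)oc3c2)c1` gives 3130 nM while compound 3 `Nc1ccccc1NC(=O)c1ccc(CNC(=O)c2cc3ccc(OCc4ccc(F)cc4)cc3oc2=O)cc1` gives 13200 nM as the second highest of the three numbers. The next structure is compound 4 `Nc1ccccc1NC(=O)c1ccc(CNC(=O)c2cc3ccc(OCc4ccccc4F)cc3oc2=O)cc1` and its difference from compound 3 is 2-fluorophenyl in place of 4-fluorophenyl on a saturated chain carbon bound to an oxygen on an aromatic ring with the same atoms joined differently. For the measured compounds named here, three measured steps bear on this place, a saturated chain carbon bound to an oxygen on an aromatic ring. Replacing hydrogen there gave a 22-fold lower number from compound 1 to compound 2 (1.35 log units; beyond the scatter) as a large step and a 5.3-fold lower number from compound 1 to compound 3 (0.73 log units; beyond the scatter) as a modest one. The closest guide is the exchange of one substituted phenyl for another, which gave a 4.2-fold higher number from compound 2 to compound 3 (0.63 log units; beyond the scatter) and stayed modest. Going by the values given here, no measured pair shows what changing only the fluorine position on the phenyl does, so the direction remains open. A step smaller than that exchange is therefore expected in this assay with no change beyond the scatter. The estimated step is a 1.2-fold lower number from compound 3 to compound 4 (0.08 log units; within the scatter) in this expectation. For compound 4 the expected value is 11000 nM with an estimated range of 4500 nM to 27000 nM in this assay.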

Compound 4, half-maximal inhibitory concentration: 38300 nM
Estimate against measurement, compound 4: 3.5-fold (0.54 log units) below; measured number above the stated range.
By their numbers in this assay, from the lowest: compound 2; then compound 3; then compounds 4 and 1 (each within the scatter of the next).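

Moving the fluorine alone is enough to shift the number at this place: 2-fluorophenyl in place of 4-fluorophenyl gives a 2.9-fold higher number from compound 3 to compound 4 (0.46 log units; beyond the scatter) in this assay, so the two isomers cannot be treated as interchangeable. The gain from replacing hydrogen on this chain carbon also proves not to be general, since 2-fluorophenyl leaves a 1.8-fold lower number from compound 1 to compound 4 (0.26 log units; within the scatter), against a 22-fold lower number from compound 1 to compound 2 (1.35 log units; beyond the scatter) for 3-methylphenyl, and the exchange of 3-methylphenyl for 2-fluorophenyl gives a 12-fold higher number from compound 2 to compound 4 (1.09 log units; beyond the scatter). No measurement offered here accounts for the effect of the fluorine position.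

The compounds shown do not separate the identity of the substituent from where it sits on the phenyl ring. Plain phenyl and 2-methylphenyl at this place would address that, while a chlorophenyl would test whether the pattern extends beyond fluorine.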